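This account rests on a few compounds, and the source may have more. Where it says the series, first, only, none or still open, it means among the compounds named here.

Measured so far, in a functional assay on MDA-MB-231 cells (Homo sapiens) for antiproliferative activity, read by MTT assay, with a stated time of 72 h; a lower number here means a stronger inhibitor, a higher number a weaker inhibitor:

Compound 1 `O=C(Nc1ccc(-c2noc(-c3cccc(NS(=O)(=O)c4cccc(Cl)c4)c3)n2)c(Cl)c1)c1cccnc1` gives > 10000 nM, a limit of this assay rather than a number.
Compound 2 `NS(=O)(=O)c1ccc(S(=O)(=O)Nc2cccc(-c3nc(-c4ccc(NC(=O)c5cccnc5)cc4Cl)no3)c2)cc1` gives > 10000 nM, likewise only a limit.
Compound 3 `CNC(=O)Nc1ccc(S(=O)(=O)Nc2cccc(-c3nc(-c4ccc(NC(=O)c5cccnc5)cc4Cl)no3)c2)cc1` gives 1300 nM.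

Compound 1 therefore stands at the limit, as described by the limit of > 10000 nM in this assay, at which 2 of the 3 values shown sit. The new compound 4 `O=C(Nc1ccccc1)Nc1cccc(-c2nc(-c3ccc(NC(=O)c4cccnc4)cc3Cl)no2)c1` differs from compound 1 by phenylcarbamoyl in place of (3-chlorophenyl)sulfonyl on a nitrogen on an aromatic ring. The measured steps that bear on it both change the group on the sulfonyl sulfur while keeping the sulfonyl itself: a step that the two limits leave unreadable from compound 1 to compound 2 and an at least 7.6-fold lower number from compound 1 to compound 3 (0.88 log units; beyond the scatter). Compound 4 instead removes the sulfonyl altogether, so those steps only loosely guide the expectation. A modest lowering is expected, an at least 3.3-fold lower number from compound 1 to compound 4 (0.52 log units; beyond the scatter), with wide uncertainty. Compound 4 is estimated at 3000 nM, in the range 500 nM to 15000 nM.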

Compound 4, half-maximal inhibitory concentration: > 10000 nM
Compound 4: a limit, no number (the forecaster's own chance of this, stated with the estimate: 40%); middle value at least 3.3-fold (0.52 log units) away from the limit.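

Among the compounds shown here, compound 1 and compound 4 each give only a limit of the assay, not a number, so no step between them can be read: the limit of > 10000 nM in this assay, at which 3 of the 4 values shown sit.
As far as these compounds go, whether phenylcarbamoyl in place of (3-chlorophenyl)sulfonyl changes activity at all stays open.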